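Dropping the Amino Group from a Chloropurine-Type Cytotoxin

The compounds below may be only part of what the source reports. "The series", "measured", "known", "first", "only" and "open" are said of these compounds alone.

Two compounds bearing a chloromethyl-substituted benzyl group on the shared core have been tested in a functional assay on SF-295 cells (Homo sapiens) for cytotoxicity, read by sulforhodamine B assay, with a stated time of 48 h; a lower number here means a stronger inhibitor of growth, a higher number a weaker inhibitor of growth. Compound 1 `Nc1nc(Cl)c2ncn(Cc3ccccc3CCl)c2n1` gives 7410 nM, the highest of the two numbers, while compound 2 `Nc1nc(Cl)c2ncn(Cc3cccc(CCl)c3)c2n1` gives 3380 nM, a lower number beyond the usual scatter. Compound 3 `ClCc1ccccc1Cn1cnc2c(Cl)ncnc21` is not yet measured; it differs from compound 1 by hydrogen in place of amino on an aromatic carbon. For the measured compounds named here, no measured pair shows this change. In this assay compound 3 is expected to lie close to compound 1, with a 1.3-fold higher number from compound 1 to compound 3 (0.13 log units; within the scatter) at most a modest step toward a higher number. Compound 3 is estimated at 10000 nM, within 3000 nM to 35000 nM.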

Compound 3, concentration for 50% growth inhibition: 10500 nM
Estimate against measurement, compound 3: 1.1-fold (0.02 log units) below, within the range that was stated.
By their numbers in this assay, from the lowest: compound 2; then compounds 1 and 3 (each within the scatter of the next).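

In this assay, for the compounds shown here, hydrogen in place of amino on the aromatic carbon between two ring nitrogen atoms gives a 1.4-fold higher number from compound 1 to compound 3 (0.15 log units; within the scatter) as the first measured step at this position. On the chloromethyl-substituted benzyl group of compound 1, then, the amino group can be lost without a step beyond the scatter. No measured evidence on these compounds bears on this result. Still open, as far as these compounds go, is whether a methylamino group, a hydroxyl or a methyl on this carbon would shift the number. Also open, from the compounds shown here alone, is whether the same change on compound 2 would give a step of similar size.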